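Three Limits and an Unmeasured Methyl Analogue

This account rests on a few compounds, and the source may have more. Where it says the series, first, only, none or still open, it means among the compounds named here.

Compound 1 `Fc1cccc(-c2nc(Nc3ccccc3F)c3cc(F)ccc3n2)c1` was examined in a functional assay on MCF7 cells (Homo sapiens) for cytotoxicity, read by MTT assay, with a stated time of 48 h; on this read-out lower numbers stand for stronger inhibition and higher numbers for weaker inhibition. In this assay compound 1 gives > 50000 nM, which is a limit of the assay and not a number. Its two neighbours stand the same way. Compound 2 `Fc1cccc(-c2nc(Nc3ccc(Br)cc3)c3cc(F)ccc3n2)c1` carries 4-bromophenyl in place of 2-fluorophenyl on a nitrogen on an aromatic ring, and compound 2 gives > 50000 nM, again a limit. Compound 3 `Oc1ccccc1Nc1nc(-c2cccc(F)c2)nc2ccc(F)cc12` carries hydroxy in place of fluoro on an aromatic carbon, and compound 3 gives > 50000 nM, also a limit. The steps a step that the two limits leave unreadable from compound 1 to compound 2, a step that the two limits leave unreadable from compound 1 to compound 3 and a step that the two limits leave unreadable from compound 2 to compound 3 are therefore not readable; what the three compounds share is captured by the limit of > 50000 nM in this assay, at which 3 of the 3 values shown sit.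

Compound 4 `Cc1cccc(Nc2nc(-c3cccc(F)c3)nc3ccc(F)cc23)c1` has not yet been measured. It differs from compound 1 in this way: 3-methylphenyl in place of 2-fluorophenyl on a nitrogen on an aromatic ring. For the measured compounds named here, no measured step gives a readable size for a change of this kind, as the limit of > 50000 nM in this assay, at which 3 of the 3 values shown sit, makes plain. The expected step is a step that the limit leaves unreadable from compound 1 to compound 4, meaning compound 4 is expected to sit at the limit as well. For compound 4 the estimate is 60000 nM, expected between 20000 nM and 200000 nM.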

Compound 4, half-maximal inhibitory concentration: > 50000 nM
Compound 4: a limit, no number (the forecaster's own chance of this, stated with the estimate: 85%); the middle value is on the limit's open side.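

In this assay compound 4 gives > 50000 nM, which is a limit of the assay and not a number. For the compounds shown here, no step linking compound 4 to compound 1, compound 2 or compound 3 can be read. The compounds shown leave open whether any change to the shared core would give a readable value: the limit of > 50000 nM in this assay, at which 4 of the 4 values shown sit.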